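The source may hold more compounds than are shown below. What is called first, only, known or untested is meant among the compounds shown, and "the series" means these compounds.

Working notes on the series.

Compound 1 `COc1cc(O)c2c(=O)cc(-c3ccccc3Cl)oc2c1CN1CCCCC1` and compound 2 `COc1cc(OC)c2c(=O)cc(-c3ccccc3Cl)oc2c1CN1CCCCC1` share a core; compound 3 `COc1cc(OC)c(C(=O)/C=C/c2ccccc2Cl)c(O)c1CN(C)CCCN(C)C` carries a different core with the same chlorophenyl group. In a functional assay on ECa-109 cells (Homo sapiens) for antiproliferative activity, with a stated time of 72 h (a higher number here means a weaker inhibitor, a lower number a stronger inhibitor), compound 1 gives 21500 nM, compound 2 gives 23700 nM, and compound 3 gives 3800 nM. Going by the values given here, the one single-point step so far, a 1.1-fold higher number from compound 1 to compound 2 (0.04 log units; within the scatter), is within the scatter. Compound 3 stands lowest of the three numbers in this assay; its gaps to compound 1 and to compound 2 both lie beyond the scatter, so on the present numbers it is the strongest inhibitor.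

Compound 4 `COc1cc(OC)c(C(=O)/C=C/c2ccccc2Cl)c(O)c1CN1CCCCC1` differs from compound 3 in one place: piperidin-1-yl in place of (3-(dimethylamino)propyl)(methyl)amino on a saturated chain carbon bound to an aromatic carbon. Among the compounds with values here, no measured step covers this change. Within the data shown here, the only step, from compound 1 to compound 2, concerns methyl in place of hydrogen on an oxygen and does not bear on the amine. Compound 1 and compound 2 carry piperidin-1-yl on a different core, so their higher numbers against compound 3 cannot be split between core and amine. With nothing directly bearing on the change, the expected step of a 1.7-fold higher number from compound 3 to compound 4 (0.23 log units; within the scatter) is set modest and toward a higher number, reflecting that both piperidin-1-yl compounds sit higher. Compound 4 is estimated at 6500 nM, with a range from 2500 nM to 17000 nM.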

Compound 4, half-maximal inhibitory concentration: 2500 nM
Compound 4: middle estimate off by 2.6-fold (0.41 log units), on the high side, and the stated range covers the measured number.
By their numbers in this assay, from the lowest: compounds 4 and 3 (each within the scatter of the next); then compounds 1 and 2 (each within the scatter of the next).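

Going by these compounds alone, this is the first measured step at this position, since the only earlier step concerned methyl in place of hydrogen on an oxygen. In this assay, the step of a 1.5-fold lower number from compound 3 to compound 4 (0.18 log units; within the scatter) lies within the scatter, so on this core the open (3-(dimethylamino)propyl)(methyl)amino group and the ring-bearing piperidin-1-yl group on a saturated chain carbon bound to an aromatic carbon cannot be told apart, and neither compound ranks above the other. The dimethylamino end of the chain is therefore not needed to hold the number in this range, at least for this pair, and no information bearing on the reason for this result is available.

The compounds shown leave open how other groups at this place would read, such as morpholin-4-yl, piperazin-1-yl, or a longer chain ending in dimethylamino. They also leave open whether the same exchange of (3-(dimethylamino)propyl)(methyl)amino for piperidin-1-yl would stay within the scatter on the core of compound 1, where only the piperidin-1-yl form appears.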